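The source may report more compounds than this note shows. Statements on the series, on what has been measured and on what is new or still open speak of the compounds shown alone.

Measured so far:
compound 1, `CC(C)=CC[C@@H](OC(=O)c1ccco1)C1=CC(=O)c2c(O)ccc(O)c2C1=O`, giving 80300 nM in a functional assay on HeLa cells (Homo sapiens) for cytotoxicity, read by MTT assay; a higher number here means a weaker inhibitor, a lower number a stronger inhibitor;
compound 2, `CCCCC(O)CC(=O)O[C@H](CC=C(C)C)C1=CC(=O)c2c(O)ccc(O)c2C1=O`, giving 72200 nM in this assay.

Compound 2 and compound 1 lie within the scatter of each other, the step being a 1.1-fold lower number from compound 1 to compound 2 (0.05 log units; within the scatter), so neither can be called the stronger. Compound 3, `CC(C)=CC[C@@H](OC(=O)CC(O)c1ccccc1)C1=CC(=O)c2c(O)ccc(O)c2C1=O`, differs from compound 2 by phenyl in place of butyl on a saturated chain carbon bound to an oxygen on a saturated carbon and a saturated chain carbon. Within the data shown here, the only measured step, a 1.1-fold lower number from compound 1 to compound 2 (0.05 log units; within the scatter), also reshaped the group on the carbonyl carbon and stayed within the scatter; no step tests this exact change. A step of about a 1.0-fold lower number from compound 2 to compound 3 (0.01 log units; within the scatter) is therefore expected, not beyond the scatter. Compound 3 is estimated to give 70000 nM, between 30000 nM and 160000 nM.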

Compound 3, half-maximal inhibitory concentration: 44500 nM
The estimate for compound 3 lay 1.6-fold (0.20 log units) above the measured number; the measured number falls inside the stated range.
By their numbers in this assay, from the lowest: compounds 3, 2 and 1 (each within the scatter of the next).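

In this assay, phenyl in place of butyl on this saturated chain carbon gives a 1.6-fold lower number from compound 2 to compound 3 (0.21 log units; within the scatter) and so an aromatic ring at this place leaves the number inside the scatter. Replacing furan-2-yl with 2-hydroxy-2-phenylethyl on the carbonyl carbon gives a 1.8-fold lower number from compound 1 to compound 3 (0.26 log units; within the scatter) and so all three groups on that carbon remain indistinguishable in this measurement. No supporting data bear on this result. As far as these compounds go, whether an amine or a carboxylic acid on this chain would produce a step beyond the scatter stays open. So does the effect of a longer chain.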